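Lengthening a Side Chain on the Weakest Measured Compound

A few compounds are considered here, and "the series" means these few. Any claim that something is new, unique, unknown or untested is made for them only; others in the source may bear on it.

Compound 1 `O=C(CN1CN(c2ccccc2)C2(CCN(C(=O)c3ccc(C4CCCCC4)cc3)CC2)C1=O)N1CCC(CO)CC1` gives 1100 nM.
Compound 2 `CC(C)(C)c1ccc(C(=O)N2CCC3(CC2)C(=O)N(CC(=O)NCN)CN3c2ccccc2)cc1` gives 26500 nM.
Compound 3 `O=C(CN1CN(c2ccccc2)C2(CCN(C(=O)c3ccc(C4CCCCC4)cc3)CC2)C1=O)NCCCCO` gives 10300 nM.

In an assay on HEK293 cells for displacement of a labelled ligand from NPC1-like intracellular cholesterol transporter 1 (Homo sapiens) (on this read-out lower numbers stand for stronger inhibition and higher numbers for weaker inhibition), compound 2 stands highest of the three, with compound 3 nearer to it and compound 1 far lower. Compound 4 `CC(C)(C)c1ccc(C(=O)N2CCC3(CC2)C(=O)N(CC(=O)NCCCCN)CN3c2ccccc2)cc1` differs from compound 2 by 3-aminopropyl in place of amino on a saturated chain carbon bound to an amide-type nitrogen. Going by the values given here, the only measured single step, a 9.4-fold higher number from compound 1 to compound 3 (0.97 log units; beyond the scatter), concerns another part of the shared core and does not bear directly on this chain extension. Compound 2 and compound 3 differ in more than one place, so their two values show only that a longer chain can sit with a lower number. Compound 4 is therefore expected to give 12000 nM, between 4000 nM and 40000 nM. The expected step is a 2.2-fold lower number from compound 2 to compound 4 (0.34 log units; beyond the scatter), toward a modestly lower number.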

Compound 4, half-maximal inhibitory concentration: 14500 nM
The estimate for compound 4 lay 1.2-fold (0.08 log units) below the measured number; measured number inside the range.
By their numbers in this assay, from the lowest: compound 1; then compounds 3, 4 and 2 (each within the scatter of the next, the first and the last beyond it).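

In this assay, a 1.8-fold lower number from compound 2 to compound 4 (0.26 log units; within the scatter) shows that, on a saturated chain carbon bound to an amide-type nitrogen, 3-aminopropyl can stand in place of amino with no difference that rises above the scatter. Going from 1 heavy atom to 4 heavy atoms in this group therefore does not separate the two compounds. No measurement shown here accounts for this result. From the compounds shown here alone, whether a carboxylic acid in place of 3-aminopropyl, or a longer chain, would set a compound clearly apart from compound 2 remains open.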